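Notes on the chain at the aromatic nitrogen, compounds 1 to 4

This account rests on a few compounds, and the source may have more. Where it says the series, first, only, none or still open, it means among the compounds named here.

Values in a functional assay on HeLa cells (Homo sapiens) for inhibition, read by trypan blue exclusion, with a stated time of 72 h; on this read-out higher numbers stand for weaker inhibition of growth and lower numbers for stronger inhibition of growth:
compound 1, `CCCn1c(-c2ccc(O)c(O)c2)c(C)c2cc(O)ccc21`: > 20000 nM, a limit of the assay and not a number
compound 2, `Cc1c(-c2ccc(O)c(O)c2)n(CCCCOc2ccccc2)c2ccc(O)cc12`: 10000 nM
compound 3, `Cc1c(-c2ccc(O)c(O)c2)n(CCCOc2ccccc2)c2ccc(O)cc12`: 18000 nM

Compound 3 holds the highest of the two numbers in this assay; its nearest neighbour is compound 2, and the step of a 1.8-fold higher number from compound 2 to compound 3 (0.26 log units; within the scatter) does not leave the scatter. Compound 1 sits at the limit noted as the limit of > 20000 nM in this assay, at which 1 of the 3 values shown sits, so its distance from the other two is not known.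

Compound 4, `Cc1c(-c2ccc(O)c(O)c2)n(C)c2ccc(O)cc12`, differs from compound 3 by hydrogen in place of 2-phenoxyethyl on a saturated chain carbon bound to an aromatic nitrogen. The measured steps that bear on this are an at least 1.1-fold lower number from compound 1 to compound 3 (0.04 log units; that floor lies within the scatter) and an at least 2.0-fold lower number from compound 1 to compound 2 (0.30 log units; that floor lies within the scatter): in both, putting the phenoxy-bearing chain onto the plain chain gave a lower number, but only to floors that lie within the scatter. The change to compound 4 runs the other way, stripping the chain back further than in compound 1. On that basis the number for compound 4 is expected to move upward in this assay, with a real chance that only a limit is returned. The estimate for compound 4 is 28000 nM, range 12000 nM to 70000 nM. This estimate implies a step of a 1.6-fold higher number from compound 3 to compound 4 (0.19 log units; within the scatter), expected but not assured to exceed the scatter.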

Compound 4, concentration for 50% growth inhibition: > 20000 nM
Compound 4: a limit, no number; the forecaster's own chance of this, stated with the estimate: 55%; the middle value lies beyond the limit too.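

In this assay compound 4 returns > 20000 nM, which is a limit of the assay and not a number. Hydrogen in place of 2-phenoxyethyl gives an at least 1.1-fold higher number from compound 3 to compound 4 (0.04 log units; that floor lies within the scatter), and hydrogen in place of 3-phenoxypropyl gives an at least 2.0-fold higher number from compound 2 to compound 4 (0.30 log units; that floor lies within the scatter), so neither floor clears the scatter and removing either phenoxy-bearing chain is not shown to change growth inhibition. The two compounds without a phenoxy group, compound 1 and compound 4, both end at the limit, and the step between them cannot be read: the limit of > 20000 nM in this assay, at which 2 of the 4 values shown sit.

As far as these compounds go, it remains open whether any group on the saturated chain carbon bound to an aromatic nitrogen can produce a step beyond the scatter, since compound 2 and compound 3 lie within the scatter of each other and the steps to the limit compounds have floors only. A chain ending in an amine or a carboxylic acid in place of the phenoxy group, or a longer chain than 3-phenoxypropyl, would show whether this position can move the number at all.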